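Stability notes: from compound 3 to compound 4

The source may hold more compounds than are shown below. What is called first, only, known or untested is meant among the compounds shown, and "the series" means these compounds.

Measured in an ADME assay on S9 fraction from liver (Rattus norvegicus) for metabolic stability, with a stated time of 1 h; a lower number here means that less of the compound is left, a higher number that more of the compound is left:
- compound 1 `N#Cc1cnc(NCc2cnccc2C(F)(F)F)cc1N[C@H]1C[C@H](O)C1`: 82%
- compound 2 `N#Cc1cnc(NCc2cnccc2C(F)(F)F)cc1N[C@H]1CC[C@@H](O)CC1`: 6%
- compound 3 `CO[C@H]1CC[C@@H](Nc2cc(NCc3cnccc3C(F)(F)F)ncc2C#N)CC1`: 1%

Compound 3 sits at the low end of these values, together with compound 2, and the gap between them stays small: a number 5 percentage points lower from compound 2 to compound 3 (within the scatter). Compound 1 stands well apart: a number 81 percentage points lower from compound 1 to compound 3 (beyond the scatter).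

The next structure is compound 4 `CO[C@H]1CC[C@@H](CNc2cc(NCc3cnccc3C(F)(F)F)ncc2C#N)CC1`, with this difference: (4-methoxycyclohexyl)methyl in place of 4-methoxycyclohexyl on a nitrogen on an aromatic ring. In words, (4-methoxycyclohexyl)methyl stands in place of 4-methoxycyclohexyl on a nitrogen on an aromatic ring.

Among the measured compounds shown here, no measured step covers this change directly. For the measured compounds named here, the nearest evidence is that both cyclohexyl compounds lie low, with the large step of a number 76 percentage points lower from compound 1 to compound 2 (beyond the scatter) alongside the one to compound 3 above. Compound 4 keeps the 4-methoxycyclohexyl group, and compound 3 at 1% leaves little room to fall. No shift beyond the scatter is expected, and the expected step is a number 2 percentage points higher from compound 3 to compound 4 (within the scatter). The estimate for compound 4 is 3%, with an expected range of 0% to 12%.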

Compound 4, percent of the compound remaining: 2%
Compound 4: the middle estimate sits 1 percentage points above what was measured; low and high end bracket the measured number.
By their numbers in this assay, from the lowest: compounds 3, 4 and 2 (each within the scatter of the next); then compound 1.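

In this assay, (4-methoxycyclohexyl)methyl in place of 4-methoxycyclohexyl on a nitrogen on an aromatic ring leaves the number within the scatter (a number 1 percentage points higher from compound 3 to compound 4 (within the scatter)), although with values this low the read-out has little room to show a further fall. Against the 4-hydroxycyclohexyl group the result is also within the scatter (a number 4 percentage points lower from compound 2 to compound 4 (within the scatter)), while the distance to the 3-hydroxycyclobutyl group stays large (a number 80 percentage points lower from compound 1 to compound 4 (beyond the scatter)), so all three compounds carrying a cyclohexyl ring now lie low and compound 1 alone stands high. Nothing available explains these numbers.

Still open, going by these compounds, is whether the high number of compound 1 goes with the cyclobutyl ring alone or needs its free hydroxyl, a question a 3-methoxycyclobutyl group would address. Also open, on these data alone, is how a cyclopentyl ring, or an amine on the cyclohexyl ring, would read in this assay.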